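Two Glutarimide Anilines Level, a Third Awaiting Its Number

The source may hold more compounds than are shown below. What is called first, only, known or untested is meant among the compounds shown, and "the series" means these compounds.

Compound 1 `O=C1CCC(N2C(=O)c3ccc(Nc4ccccn4)cc3C2=O)C(=O)N1`: 9%
Compound 2 `Cc1ccc(Nc2cccc3c2C(=O)N(C2CCC(=O)NC2=O)C3=O)cc1`: 9%

In an assay on FRT-Jurkat cells for inhibition of nuclear factor NF-kappa-B complex (Homo sapiens), read by flow cytometry, with a stated time of 24 h, tested at 10 uM (on this read-out lower numbers stand for less inhibition and higher numbers for more inhibition at the one concentration tested (going by the name of the read-out)), compound 1 gives 9%, and in the same assay compound 2 gives 9%, so compound 1 stands level with compound 2 within the scatter. Compound 3 `CCc1ccc(Nc2ccc3c(c2)C(=O)N(C2CCC(=O)NC2=O)C3=O)cc1` is not yet measured. It differs from compound 1 by 4-ethylphenyl in place of pyridin-2-yl on a nitrogen on an aromatic ring. With both measured compounds sitting at the same low level, no step beyond the scatter is expected, and the change from compound 1 to compound 3 is estimated as a number 1 percentage points higher from compound 1 to compound 3 (within the scatter). Compound 3 is therefore expected to give about 10%, between 0% and 25%.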

Compound 3, a percentage reported as inhibition, at one concentration (the size of the read-out at that concentration, not a potency): 5%
Compound 3: the middle estimate sits 5 percentage points above what was measured; the measured number falls inside the stated range.
By their numbers in this assay, from the lowest: compounds 3, 1 and 2 (each within the scatter of the next).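

In this assay, 4-ethylphenyl in place of pyridin-2-yl on a nitrogen on an aromatic ring gives a number 4 percentage points lower from compound 1 to compound 3 (within the scatter) and so does not lift the read-out out of its low range. At this position, then, a ring of carbon only bearing an ethyl group reads the same, within the scatter, as a ring with a hetero atom. No evidence bears on why this exchange leaves the read-out within the scatter. Still open, from the compounds shown here alone, is whether a carboxylic acid, an amine or a longer chain on this ring would give more inhibition.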